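Double-bond geometry in a bis-amide series, cytotoxicity notes

This account rests on a few compounds, and the source may have more. Where it says the series, first, only, none or still open, it means among the compounds named here.

Measured so far in a functional assay on HT-29 cells (Homo sapiens) for cytotoxicity, read by MTT assay, with a stated time of 48 h; a higher number here means a weaker inhibitor, a lower number a stronger inhibitor
- compound 1 (`COC(=O)[C@@H]1CCCN1C(=O)C1=C(C)NC(=S)NC1c1ccc(OCCCOc2ccc(C3NC(=S)NC(C)=C3C(=O)N3CCC[C@H]3C(=O)OC)cc2OC)c(OC)c1`): (> 200 ug/mL), a limit
- compound 2 (`COC(=O)[C@@H]1CCCN1C(=O)C1=C(C)NC(=S)NC1c1ccc(OC/C=C\COc2ccc(C3NC(=S)NC(C)=C3C(=O)N3CCC[C@H]3C(=O)OC)cc2OC)c(OC)c1`): (> 200 ug/mL), a limit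

Both entries are limits of the assay and not numbers. Compound 2 has only a limit (> 200 ug/mL) to its name. Its standing is shared, since the limit of > 200 ug/mL in this assay, at which 2 of the 2 values shown sit, and no measured number exists on either side of it.

Against compound 2, compound 3 (`COC(=O)[C@@H]1CCCN1C(=O)C1=C(C)NC(=S)NC1c1ccc(OC/C=C/COc2ccc(C3NC(=S)NC(C)=C3C(=O)N3CCC[C@H]3C(=O)OC)cc2OC)c(OC)c1`) shows a single difference (the two compounds have the same atoms and bonds; at least one stereo element is drawn with a configuration in one of them and without one in the other: 1 of 5 stereo elements differ; a double bond is drawn Z in compound 2 and E in compound 3): the two compounds have the same atoms and bonds, and a double bond is drawn Z in compound 2 and E in compound 3.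

Among the compounds with values here, no measured step is available to size this change. With compound 2 held at its limit (> 200 ug/mL), no step beyond the usual scatter is expected in this assay and no direction is favoured. The estimated step that the limit leaves unreadable from compound 2 to compound 3 is accordingly small. For compound 3 the expected value is 220 ug/mL within the range 120 ug/mL to 400 ug/mL and the assay may well report only a limit again.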

Compound 3, half-maximal inhibitory concentration: > 200 ug/mL
Compound 3 was reported as a limit (the forecaster's own chance of this, stated with the estimate: 80%); the middle value lies beyond the limit too.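

In this assay compound 3 gives > 200 ug/mL, a limit of the assay and not a number. No step from compound 2 to compound 3 can be read: the limit of > 200 ug/mL in this assay, at which 3 of the 3 values shown sit.

The compounds shown leave open whether a double bond drawn Z in compound 2 and E in compound 3 changes the read-out in this assay at all.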